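The source may hold more compounds than are shown below. What is called first, only, known or untested is meant among the compounds shown, and "the series" means these compounds.

Within the data shown here, in a functional assay on FaDu cells (Homo sapiens) for cytotoxicity, read by MTT assay, with a stated time of 72 h (on this read-out lower numbers stand for higher toxicity in this test and higher numbers for lower toxicity in this test), compound 1 (`COc1ccc(NC(=O)C(=O)c2cn(C(C)C)c3ccccc23)cc1`) gives 181 nM, the only actual number in this small set. Compound 2 (`COc1ccc(NC(=O)C(=O)c2cn(C(C)C)c3ccc(Cl)cc23)cc1`) reads > 10000 nM, which is a limit of the assay and not a number. Compound 3 (`COc1ccc(NC(=O)C(=O)c2cn(C(C)C)c3ccccc23)cc1OC`) reads > 10000 nM, likewise a limit. The set is therefore marked by the limit of > 10000 nM in this assay, at which 2 of the 3 values shown sit.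

Both measured steps are large and beyond the scatter. Chloro in place of hydrogen on an aromatic carbon gives an at least 55-fold higher number from compound 1 to compound 2 (1.74 log units; beyond the scatter), and methoxy in place of hydrogen on an aromatic carbon gives an at least 55-fold higher number from compound 1 to compound 3 (1.74 log units; beyond the scatter). The second of these alters the 4-methoxyphenyl group itself, and that group is what leaves in compound 4 (`COc1nc(NC(=O)C(=O)c2cn(C(C)C)c3ccccc23)ns1`). The change is a group of 7 heavy atoms (3 carbon, 2 nitrogen, 1 oxygen, 1 sulfur; one five-membered aromatic ring with 3 hetero atoms) in place of a group of 8 heavy atoms (7 carbon, 1 oxygen; one six-membered aromatic ring of carbon only), on an amide-type nitrogen, which puts a five-membered aromatic ring with 3 hetero atoms in place of a six-membered aromatic ring of carbon only, on an amide-type nitrogen.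

Among the measured compounds shown here, no measured step makes this exchange directly, so the two steps serve only as a guide. Given an at least 55-fold higher number from compound 1 to compound 3 (1.74 log units; beyond the scatter), a large step toward a higher number is expected in this assay, although its size is uncertain and a limit reading is quite possible. The estimated step is a 17-fold higher number from compound 1 to compound 4 (1.22 log units; beyond the scatter). For compound 4 the estimated value is 3000 nM, with an expected range from 400 nM to 10000 nM.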

Compound 4, concentration lethal to 50% of the cells: > 10000 nM
Compound 4: no number, only a limit (the forecaster's own chance of this, stated with the estimate: 45%); middle value at least 3.3-fold (0.52 log units) away from the limit.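

With the 4-methoxyphenyl group replaced outright on the amide-type nitrogen, and not merely given a second methoxy as in compound 3, the change gives an at least 55-fold higher number from compound 1 to compound 4 (1.74 log units; beyond the scatter) in this assay. Compound 4 reads > 10000 nM, which is a limit of the assay and not a number. Two different changes to the group on this nitrogen, one adding to the six-membered ring and one exchanging it for a five-membered aromatic ring with 3 hetero atoms, now end at the same reading, and compound 1 remains the only compound in the set with an actual number: the limit of > 10000 nM in this assay, at which 3 of the 4 values shown sit.

As far as these compounds go, how large the step from compound 1 really is stays unknown, and so does whether the loss belongs to the five-membered ring itself or to the departure of the 4-methoxyphenyl group as such. The compounds shown leave open what a plain phenyl, a 4-chlorophenyl or a pyridine ring would give on this nitrogen, and whether a group other than isopropyl on the shared core would change the picture.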